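Linker length between thiadiazole and indole: compound 3

A few compounds are considered here, and "the series" means these few. Any claim that something is new, unique, unknown or untested is made for them only; others in the source may bear on it.

The shared core is kept throughout; the compounds differ only in the saturated chain that joins the indole to the rest of the molecule. Compound 1 `C/C(=N/c1nnc(Cc2c[nH]c3ccccc23)s1)c1cc2cc(Br)ccc2oc1=O` gives in an ADME assay on Vero cells (Chlorocebus sabaeus) for inhibition, read by MTT assay, with a stated time of 48 h (on this read-out higher numbers stand for weaker inhibition and lower numbers for stronger inhibition), a value of 113000 nM. Compound 2 `C/C(=N/c1nnc(CCCc2c[nH]c3ccccc23)s1)c1cc2cc(Br)ccc2oc1=O` gives in this assay a value of 116000 nM. Within the data shown here, compound 2 has the highest of the two numbers so far; its nearest neighbour is compound 1, whose number is within the scatter of it, so the two cannot be told apart on these data.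

Compound 3 `C/C(=N/c1nnc(CCc2c[nH]c3ccccc23)s1)c1cc2cc(Br)ccc2oc1=O` sits between them in chain length, carrying (1H-indol-3-yl in place of (1H-indol-3-yl)methyl on a saturated chain carbon, two bonds along the chain from an aromatic carbon). Among the measured compounds shown here, no step between measured compounds is available for this kind of change, but compound 1 and compound 2, with the shortest and longest chains, give numbers within the scatter of each other. The step of a 1.0-fold lower number from compound 2 to compound 3 (0.00 log units; within the scatter) is therefore expected to be none beyond the scatter, in no set direction. For compound 3 a value of about 115000 nM in this assay is estimated, with a range from 70000 nM to 190000 nM.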

Compound 3, half-maximal inhibitory concentration: 43100 nM
Compound 3: the middle estimate sits 2.7-fold (0.43 log units) above what was measured, and the stated range ends above it.
By their numbers in this assay, from the lowest: compound 3; then compounds 1 and 2 (each within the scatter of the next).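

In this assay the saturated chain proves to be a position that can move the number: the change gives a 2.7-fold lower number from compound 2 to compound 3 (0.43 log units; beyond the scatter), and the opposite comparison with the shortest chain gives a 2.6-fold lower number from compound 1 to compound 3 (0.42 log units; beyond the scatter), both modest but beyond the scatter. Compounds 1 and 2 alone suggested that chain length made no difference, whereas the three compounds together show no steady trend with length: the intermediate chain of compound 3 has the lowest number, while the shorter chain of compound 1 and the longer chain of compound 2 remain within the scatter of each other. No measurement at hand accounts for this difference.

Open, going by these compounds, is whether the lower number is specific to the chain of compound 3 or whether a longer chain than that of compound 2 would also shift the number in this assay. Also open, on these data alone, is whether the step would survive a chain carrying a methyl branch, or one with an ether oxygen or an amine in place of a chain carbon, and these changes would test how narrowly the effect depends on the chain itself.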